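The compounds below may be only part of what the source reports. "The series", "measured", "known", "first", "only" and "open" are said of these compounds alone.

compound 1 `O=C(NC1CCCCC1)Oc1ccc(Cl)cc1C(=O)Nc1ccc(Br)cc1`: 9400 nM
compound 2 `O=C(Nc1ccccc1)Oc1ccc(Cl)cc1C(=O)Nc1ccc(Br)cc1`: 5450 nM
compound 3 `O=C(NCc1ccccc1)Oc1ccc(Cl)cc1C(=O)Nc1ccc(C(F)(F)F)cc1`: 3000 nM

All three numbers come from an ADME assay on HepG2 cells (Homo sapiens), read by MTT assay, with a stated time of 72 h, in the presence of a further agent that is not named here; a lower number here means a stronger inhibitor, a higher number a weaker inhibitor. Compound 3 has the lowest number of the three, although it lies within the scatter of compound 2 and beyond the scatter only against compound 1. Compound 4 `O=C(NCc1ccccc1)Oc1ccc(Cl)cc1C(=O)Nc1ccc(Br)cc1` differs from compound 3 in one place, with bromo in place of trifluoromethyl on an aromatic carbon. Going by the values given here, no measured step makes this swap. Among the compounds with values here, the only measured step, a 1.7-fold lower number from compound 1 to compound 2 (0.24 log units; within the scatter), concerns a different place in the molecule. Compounds 1 and 2 do carry the 4-bromophenyl, but they differ from compound 4 elsewhere. A shift beyond the scatter is therefore not expected, and the estimated step is a 1.3-fold higher number from compound 3 to compound 4 (0.12 log units; within the scatter). For compound 4 the expected value is 4000 nM, with an estimated range of 1800 nM to 9000 nM.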

Compound 4, half-maximal inhibitory concentration: 1650 nM
Compound 4: middle estimate off by 2.4-fold (0.38 log units), on the high side; the whole stated range lies above it.
By their numbers in this assay, from the lowest: compounds 4, 3, 2 and 1 (each within the scatter of the next, the first and the last beyond it).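

Bromo in place of trifluoromethyl gives a 1.8-fold lower number from compound 3 to compound 4 (0.26 log units; within the scatter) and so does not separate these two groups at this position. With the 4-bromophenyl held fixed, the group on the amide-type nitrogen does separate the compounds: benzyl in place of phenyl gives a 3.3-fold lower number from compound 2 to compound 4 (0.52 log units; beyond the scatter) and benzyl in place of cyclohexyl gives a 5.7-fold lower number from compound 1 to compound 4 (0.76 log units; beyond the scatter) and both steps lie beyond the scatter. Nothing measured here explains these steps.

Still open, as far as these compounds go, is how a longer chain in place of benzyl would read. From the compounds shown here alone, it is also open whether a nitrile or a carboxylic acid in place of bromo would stay level with bromo and trifluoromethyl.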